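The source may hold more compounds than are shown below. What is called first, only, known or untested is meant among the compounds shown, and "the series" means these compounds.

Measured so far:
compound 1, `CN(Cc1cccc(C(=O)O)c1)c1ccc(OCc2c(-c3c(Cl)cccc3Cl)noc2C2CC2)nc1C(F)(F)F` — 2 nM
compound 2, `CC(C)c1onc(-c2c(Cl)cccc2Cl)c1COc1ccc(N(C)Cc2cccc(C(=O)NCCOP(=O)(O)O)c2)c(C(F)(F)F)n1` — 216 nM
compound 3, `O=C(O)c1ccccc1OCc1ccc(OCc2c(-c3c(Cl)cccc3Cl)noc2C2CC2)nc1C(F)(F)F` — 611 nM

These three compounds were tested in a functional assay on HEK293 cells for agonist activity at Bile acid receptor (Homo sapiens), read by a luciferase reporter; a higher number here means that more compound is needed for the effect, a lower number that less compound is needed. Compound 3, `O=C(O)c1ccccc1OCc1ccc(OCc2c(-c3c(Cl)cccc3Cl)noc2C2CC2)nc1C(F)(F)F`, gives the highest number of the three in this assay with 611 nM: compound 2 comes nearest with a lower number, and compound 1 is furthest with a much lower number. For the measured compounds named here, the one step measured between compounds that differ in a single place is a 310-fold higher number from compound 1 to compound 3 (2.49 log units; beyond the scatter), in which the (3-carboxybenzyl)(methyl)amino group of compound 1 is exchanged for a (2-carboxyphenoxy)methyl group.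

Compound 4, `O=C(O)c1ccc(OCc2ccc(OCc3c(-c4c(Cl)cccc4Cl)noc3C3CC3)nc2C(F)(F)F)cc1`, has not yet been measured in this assay. It is built from the same atoms as compound 3, joined differently: 4-carboxyphenyl in place of 2-carboxyphenyl on an oxygen on a saturated carbon. Only the position of the carboxylic acid on the terminal ring moves; the rest of the molecule is unchanged.

Going by the values given here, no measured step here moves a carboxylic acid around a ring, so none of them bears directly on this change; the step from compound 1 to compound 3 alters the linker as well as the acid position and cannot be separated into its parts. The expectation therefore rests on compound 3 alone, with a wide range, and a modest improvement seems plausible: compound 4 is expected to give 250 nM (between 40 nM and 1500 nM), a step of a 2.4-fold lower number from compound 3 to compound 4 (0.39 log units; beyond the scatter).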

Compound 4, half-maximal effective concentration: 38 nM
Estimate against measurement, compound 4: 6.6-fold (0.82 log units) above, and the stated range ends above it.
By their numbers in this assay, from the lowest: compound 1; then compound 4; then compound 2; then compound 3.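

In this assay, moving the carboxylic acid around the terminal ring while keeping every atom of the molecule gives a 16-fold lower number from compound 3 to compound 4 (1.21 log units; beyond the scatter) and shows that the place of the acid alone can change the result strongly on this oxygen-linked ring. The 4-carboxyphenyl group closes only part of the gap to the compound with the (3-carboxybenzyl)(methyl)amino group, since there remains a 19-fold higher number from compound 1 to compound 4 (1.28 log units; beyond the scatter) and this step changes the linker and the place of the acid together, so the two contributions cannot be told apart. No measurement is available here that would explain why the acid's place matters so much.

The compounds shown leave open how a 3-carboxyphenyl group would behave on the same oxygen, which would help separate the effect of the acid's place from that of the linker. They also leave open whether the carboxylic acid of the 4-carboxyphenyl group is itself needed, or whether a primary amide or a tetrazole could take its place.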